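Growing the methoxy of compound 3 into a benzyloxy

The compounds below may be only part of what the source reports. "The series", "measured", "known", "first", "only" and "open" are said of these compounds alone.

Compound 3 `COc1ccccc1/C=C/C=C1\SC(=S)NC1=O` stands second highest of the three numbers in an assay on isolated protein for inhibition of protein tyrosine phosphatase type IVA 3 (Homo sapiens), tested at 5 ug/mL (on this read-out higher numbers stand for more inhibition at the one concentration tested (going by the name of the read-out) and lower numbers for less inhibition), with 41.7%. Compound 1 `O=C1NC(=S)S/C1=C\C=C\c1ccccc1` gives 37.4%, and a number 4.3 percentage points higher from compound 1 to compound 3 (within the scatter) stays within the scatter. Compound 2 `COc1cccc(COc2ccccc2/C=C/C=C2\SC(=S)NC2=O)c1` gives 52.9%, and a number 11.2 percentage points lower from compound 2 to compound 3 (beyond the scatter) lies beyond the scatter. Compound 4 `O=C1NC(=S)S/C1=C\C=C\c1ccccc1OCc1ccccc1` differs from compound 3 by phenyl in place of hydrogen on a saturated chain carbon bound to an oxygen on an aromatic ring. The step from compound 2 to compound 3, which exchanged 3-methoxyphenyl for hydrogen on a saturated chain carbon bound to an oxygen on an aromatic ring, bears most directly on this change and was modest in size; the step from compound 1 to compound 3 is less related and stayed within the scatter. Compound 4 is therefore expected to show a modest gain, a number 9.3 percentage points higher from compound 3 to compound 4 (within the scatter), in this assay. The estimate for compound 4 is 51%, with a range from 39% to 63%.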

Compound 4, a percentage reported as inhibition, at one concentration (the size of the read-out at that concentration, not a potency): 49.5%
Compound 4: middle estimate off by 1.5 percentage points, on the high side; the measured number falls inside the stated range.
By their numbers in this assay, from the lowest: compounds 1, 3, 4 and 2 (each within the scatter of the next, the first and the last beyond it).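

Phenyl in place of hydrogen on the saturated chain carbon does not by itself pass the scatter, with a number 7.8 percentage points higher from compound 3 to compound 4 (within the scatter). The whole benzyloxy group does pass it, with a number 12.1 percentage points higher from compound 1 to compound 4 (beyond the scatter), which methoxy in that place did not. Hydrogen in place of methoxy on the added ring also stays within the scatter, with a number 3.4 percentage points lower from compound 2 to compound 4 (within the scatter), and the methoxy change reads alike on both cores: the same change on two cores in this assay, a number 4.3 percentage points higher (within the scatter) from compound 1 to compound 3 and a number 3.4 percentage points higher (within the scatter) from compound 4 to compound 2, 0.9 percentage points apart, within the scatter of two such steps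

On these data alone, whether a longer chain between the oxygen and the phenyl would pass the scatter from compound 3 stays open. So does the effect of an amine or a carboxylic acid on that phenyl.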